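This account rests on a few compounds, and the source may have more. Where it says the series, first, only, none or still open, it means among the compounds named here.

Measured so far:
compound 1 `Cn1nc(CN2CCCC2)nc1-c1ccc(C(C)(C)C)cc1` gives 7.5 nM in an assay on membranes from Jurkat cells for displacement of a labelled ligand from Sigma non-opioid intracellular receptor 1 (Homo sapiens), read by scintillation counting, with a stated time of 2 h; a lower number here means a stronger inhibitor, a higher number a weaker inhibitor
compound 2 `Cn1nc(CN2CCCC2)nc1-c1cccc(C(C)(C)C)c1` gives 29 nM in this assay

Two compounds share the same core and differ only in where the tert-butyl group sits on the phenyl ring. Of the two numbers, compound 2 carries the higher one, so it is the weaker binder of the pair, and the gap to compound 1 lies beyond the usual scatter of this assay. Compound 3 `Cn1nc(CN2CCCC2)nc1-c1cccc(C2(C(F)(F)F)CC2)c1` is not yet measured. It keeps everything in compound 2 except one group: 1-(trifluoromethyl)cyclopropyl in place of tert-butyl on an aromatic carbon. The group that enters is larger, and it brings three fluorine atoms and a small ring where compound 2 had a plain branched chain. Among the compounds with values here, no measured pair in this set shows what such a swap does, so the expectation rests on compound 2 alone. A change of this kind is expected to shift the number only modestly, without a clear direction beyond the scatter; the step of a 1.4-fold higher number from compound 2 to compound 3 (0.14 log units; within the scatter) is therefore estimated to be small. Compound 3 is expected to give about 40 nM in this assay, within a range from 12 nM to 130 nM.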

Compound 3, inhibition constant: 32 nM
Compound 3: the middle estimate sits 1.3-fold (0.10 log units) above what was measured, within the range that was stated.
By their numbers in this assay, from the lowest: compound 1; then compounds 2 and 3 (each within the scatter of the next).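

In this assay, putting 1-(trifluoromethyl)cyclopropyl in place of tert-butyl on this aromatic carbon gives a 1.1-fold higher number from compound 2 to compound 3 (0.04 log units; within the scatter) and so leaves the two compounds indistinguishable. Within the data shown here, this is the first direct look at a change at this position. The entering group has 7 heavy atoms rather than 4, and it adds three fluorine atoms and a three-membered ring, yet this larger group gives no difference that can be separated from ordinary measurement noise. For this single pair, then, binding in this assay tolerates the exchange of one of these groups for the other, although one pair cannot establish a general rule for this position. The data offered here give no explanation for why the two groups read alike.

Still open, as far as these compounds go, is whether 1-(trifluoromethyl)cyclopropyl would behave the same way on the ring carbon that carries tert-butyl in compound 1, since that comparison would test the swap at a second position. It is also unknown how far this tolerance extends to quite different groups on the aromatic carbon of compound 2, such as a carboxylic acid, an amine or a longer carbon chain.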